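The compounds below may be only part of what the source reports. "The series", "measured", "known", "first", "only" and "open" are said of these compounds alone.

Three compounds were measured in a functional assay on LNCaP cells (Homo sapiens) for antiproliferative activity, read by CCK-8 assay, with a stated time of 6 days; on this read-out lower numbers stand for stronger inhibition and higher numbers for weaker inhibition:

compound 1 `C[C@@H](Cn1ccc(-c2ccc(C#N)c(Cl)c2)n1)NC(=O)c1ccccc1`, compound 1 gives 1830 nM
compound 2 `COC(=O)/C=C/C(=O)N[C@@H](C)Cn1ccc(-c2ccc(C#N)c(Cl)c2)n1`, compound 2 gives 2460 nM
compound 3 `CC(=O)c1ccc(S(=O)(=O)N[C@@H](C)Cn2ccc(-c3ccc(C#N)c(Cl)c3)n2)cc1`, compound 3 gives 5230 nM

Compound 3 carries the highest number of the three, with compound 2 nearest and compound 1 furthest from it, both gaps lying beyond the scatter. Going by the values given here, the only step between measured compounds that differ in one place is a 1.3-fold higher number from compound 1 to compound 2 (0.13 log units; within the scatter), which concerns the substituent on the amide carbonyl and not the sulfonyl tail.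

Compound 4 `C[C@@H](Cn1ccc(-c2ccc(C#N)c(Cl)c2)n1)NS(=O)(=O)c1cccnc1` is compound 3 with pyridin-3-yl in place of 4-acetylphenyl on a sulfonyl sulfur. Among the compounds with values here, no measured step addresses an exchange on the sulfonyl sulfur, so the expectation for compound 4 rests on the fact that the one exchange at the tail end of the shared core, from compound 1 to compound 2, stayed within the scatter, and on the observation that the sulfonamide of compound 3 sits at the high end of the three numbers. On that basis compound 4 is expected to give about 4000 nM in this assay, with a range from 1500 nM to 12000 nM. The step this estimate implies, a 1.3-fold lower number from compound 3 to compound 4 (0.12 log units; within the scatter), is expected to be small, with no direction claimed beyond the scatter.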

Compound 4, half-maximal inhibitory concentration: 6140 nM
Beside the measured number, compound 4's estimate is 1.5-fold (0.19 log units) below it; low and high end bracket the measured number.
By their numbers in this assay, from the lowest: compounds 1 and 2 (each within the scatter of the next); then compounds 3 and 4 (each within the scatter of the next).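

On the sulfonyl sulfur, the exchange of 4-acetylphenyl for pyridin-3-yl produces a 1.2-fold higher number from compound 3 to compound 4 (0.07 log units; within the scatter) in this assay and so makes no difference beyond the scatter, even though a carbon-only ring with its acetyl gives way to a ring with one hetero atom and fewer heavy atoms. The exchange on the amine nitrogen does exceed the scatter, with a 2.5-fold higher number from compound 2 to compound 4 (0.40 log units; beyond the scatter) when (pyridin-3-yl)sulfonyl replaces (2-(methoxycarbonyl)ethenyl)carbonyl and a 3.4-fold higher number from compound 1 to compound 4 (0.53 log units; beyond the scatter) when it replaces benzoyl, so that among these four compounds the two sulfonamides, compound 3 and compound 4, sit above the two amides, compound 1 and compound 2, with no compound going against that split. No evidence is available on what lies behind this split or behind the flat result on the sulfonyl sulfur.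

Still open, from the compounds shown here alone, is whether a sulfonyl group carrying a small alkyl such as methyl, or a ring bearing an amine or a carboxylic acid, would stay with compound 3 and compound 4. Also open, going by these compounds, is how an amide with pyridin-3-yl on the carbonyl carbon would compare with compound 1, a pair that would separate the effect of the ring from that of the sulfonyl link.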